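Tolyl sulfonamide variant of an inactive trypsin series

A few compounds are considered here, and "the series" means these few. Any claim that something is new, unique, unknown or untested is made for them only; others in the source may bear on it.

Compound 1 `CCOc1cc(C(Nc2ccc3cnccc3c2)C(=O)NS(=O)(=O)c2ccccc2)ccc1OC(C)C` gives in an assay on isolated protein for inhibition of Trypsin (Homo sapiens) (a lower number here means a stronger inhibitor, a higher number a weaker inhibitor), the limit > 5000 nM.
Compound 2 `CCOc1cc(C(Nc2ccc3c(N)nccc3c2)C(=O)NS(=O)(=O)c2cccc(CO)c2)ccc1OC(C)C` gives in this assay the limit > 5000 nM.
Compound 3 `CCOc1cc(C(Nc2ccc3c(N)nccc3c2)C(=O)NS(=O)(=O)c2cccc(S(N)(=O)=O)c2)ccc1OC(C)C` gives in this assay the limit > 5000 nM.

Compound 2 stands at the edge of what this assay can report: its value is a limit, not a number, and the two other values shown are limits as well, so nothing places it higher or lower than compound 1 or compound 3.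

The step to the unmeasured compound 4 `CCOc1cc(C(Nc2ccc3c(N)nccc3c2)C(=O)NS(=O)(=O)c2ccc(C)cc2)ccc1OC(C)C` is 4-methylphenyl in place of 3-(hydroxymethyl)phenyl on a sulfonyl sulfur. Among the compounds with values here, the only measured step at the same position is a step that the two limits leave unreadable from compound 2 to compound 3, and it cannot be read as a size because both of its ends are limits. Within the data shown here, what the data offer is the limit of > 5000 nM in this assay, at which 3 of the 3 values shown sit, which says that every value so far sits at the same limit, and no measured step tells how much the sulfonyl substituent matters.

Compound 4 is therefore expected to give a limit again rather than a number, with the step that the limit leaves unreadable from compound 2 to compound 4 expected to stay within the scatter. The estimate for compound 4 in this assay is 9000 nM, in a range from 3000 nM to 40000 nM.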

Compound 4, inhibition constant: 3040 nM
Estimate against measurement, compound 4: 3.0-fold (0.47 log units) above; measured number inside the range.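

With 4-methylphenyl on the sulfonyl sulfur, compound 4 gives 3040 nM in this assay, the first number rather than a limit in this set, so this position can carry a group for which the assay reports a value. On these data alone, the result gives only floors: an at least 1.6-fold lower number from compound 2 to compound 4 (0.21 log units; that floor lies within the scatter), and an at least 1.6-fold lower number from compound 3 to compound 4 (0.21 log units; that floor lies within the scatter), so the true size of either step remains unknown and may or may not exceed the scatter. The change removes the hydrogen-bond donor and acceptor counted in 3-(hydroxymethyl)phenyl and also alters where the substituent sits on the aromatic ring, while most of the values still give no number to compare: the limit of > 5000 nM in this assay, at which 3 of the 4 values shown sit.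

These compounds do not separate the effect of the methyl group from the effect of its place on the ring, so either could account for the number seen with compound 4. As far as these compounds go, it also remains open how the value would respond to an unsubstituted phenyl on the same core, or to an ethyl group, a longer alkyl chain, an amine or a carboxylic acid in place of the methyl.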